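Aryl group exchange on the benzyl urea series

The compounds below may be only part of what the source reports. "The series", "measured", "known", "first", "only" and "open" are said of these compounds alone.

Measured compounds in a functional assay on a cell-free system (plasma) with sterol O-acyltransferase, Soat (Rattus norvegicus) as the target; on this read-out lower numbers stand for an effect already at smaller amounts and higher numbers for an effect only at larger amounts of compound:
compound 1, `Cc1cc(C)c(NC(=O)N(Cc2ccc(-c3n[nH]c(C)n3)cc2)C2CCCCCC2)c(C)c1`, > 1 mg/kg.
compound 2, `Cc1cc(C)c(NC(=O)N(Cc2ccc(-c3cccs3)cc2)C2CCCCCC2)c(C)c1`, 0.28 mg/kg.

For compound 1 the entry > 1 mg/kg is a limit of the assay and not a number. Compound 2 thus carries the only number shown in this assay, the other entry sitting at the limit of > 1 mg/kg in this assay, at which 1 of the 2 values shown sits. Within the data shown here, the single measured step, an at least 3.5-fold lower number from compound 1 to compound 2 (0.55 log units; beyond the scatter), shows that the aromatic group attached to the benzyl ring governs the read-out, with the 5-methyl-1H-1,2,4-triazol-3-yl analogue reaching only the limit.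

Compound 3, `Cc1cc(C)c(NC(=O)N(Cc2ccc(-c3ccccn3)cc2)C2CCCCCC2)c(C)c1`, is not yet measured. It differs from compound 2 by pyridin-2-yl in place of thiophen-2-yl on an aromatic carbon. Among the measured compounds shown here, the measured step bears on this change only loosely: it sets thiophen-2-yl above the triazolyl group, but a six-membered aromatic ring at this place has no precedent here. A step of a 1.8-fold higher number from compound 2 to compound 3 (0.25 log units; within the scatter) in this assay is expected, toward larger amounts but short of the limit, since pyridin-2-yl lies between the two measured groups in ring size and type. For compound 3 the estimated value is 0.5 mg/kg, with a range from 0.2 mg/kg to 1.5 mg/kg.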

Compound 3, dose for half-maximal effect: > 1 mg/kg
Compound 3 ended at the assay's limit; the forecaster's own chance of this, stated with the estimate: 25%; middle value at least 2.0-fold (0.30 log units) away from the limit.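

In this assay compound 3 gives > 1 mg/kg, which is a limit of the assay and not a number. The exchange of thiophen-2-yl for pyridin-2-yl on an aromatic carbon, para to a large group, gives an at least 3.5-fold higher number from compound 2 to compound 3 (0.55 log units; beyond the scatter), so the loss seen with the triazolyl group is not confined to that group and also appears with a six-membered aromatic ring that has the same hydrogen-bond donor and acceptor counts and no net charge as the thiophen-2-yl group. Of the three groups shown at this place, only thiophen-2-yl gives a number, and the step between compound 1 and compound 3 cannot be read, as both entries are limits: the limit of > 1 mg/kg in this assay, at which 2 of the 3 values shown sit.

On these data alone, it remains open whether the number of compound 2 depends on the sulfur atom or on the five-membered ring, a question that furan-2-yl or thiophen-3-yl at this place would address. Whether phenyl, which has no hetero atom, keeps a number in this assay or also ends at the limit is equally unsettled.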